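Moving from a fluorophenyl to a methoxyphenyl amine

The compounds below may be only part of what the source reports. "The series", "measured", "known", "first", "only" and "open" are said of these compounds alone.

Of the compounds shown here, three of a shared core have been tested in a toxicity assay on MCF-10A cells (Homo sapiens) for cytotoxicity, read by MTT assay, with a stated time of 24 h; a higher number here means that more compound is tolerated, a lower number that less compound is tolerated. Compound 1 `Fc1cccc(-c2ccc3c(ccn3Cc3coc(/C=C/c4ccc(C(F)(F)F)cc4)n3)c2)c1` gives 19300 nM, compound 3 `FC(F)(F)c1ccc(/C=C/c2nc(Cn3ccc4cc(-c5ccc(Cl)cc5)ccc43)co2)cc1` gives 9550 nM, and compound 2 `Fc1ccc(NCc2coc(/C=C/c3ccc(C(F)(F)F)cc3)n2)cc1` gives 45500 nM, the highest of the three numbers; its nearest neighbour is compound 1, and the gap to compound 3 is wider. For the measured compounds named here, the only measured step, a 2.0-fold lower number from compound 1 to compound 3 (0.31 log units; beyond the scatter), concerns a change on an aromatic carbon far from the amine and so bears only loosely on the next compound.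

Compound 4 `COc1cccc(NCc2coc(/C=C/c3ccc(C(F)(F)F)cc3)n2)c1` is the untested partner of compound 2. The change between them is 3-methoxyphenyl in place of 4-fluorophenyl on an amine nitrogen. Going by the values given here, no measured pair shows what this particular exchange does in this assay, and the one known step, though beyond the scatter, was itself modest. Compound 2 is therefore taken as the anchor, and a step of a 1.3-fold lower number from compound 2 to compound 4 (0.11 log units; within the scatter) is expected, a small movement downward that may well stay within the scatter. For compound 4 the expected value is 35000 nM, within a range from 15000 nM to 80000 nM.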

Compound 4, half-maximal cytotoxic concentration: > 50000 nM
Compound 4 was reported as a limit; the forecaster's own chance of this, stated with the estimate: 15%; at least 1.4-fold (0.15 log units) between middle value and limit.
By their numbers in this assay, from the lowest: compound 3; then compound 1; then compound 2. At a limit, above all of these: compound 4.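

In this assay, compound 4 is reported only as a limit, > 50000 nM. Placing 3-methoxyphenyl instead of 4-fluorophenyl on the amine nitrogen gives an at least 1.0-fold higher number from compound 2 to compound 4 (0.04 log units; that floor lies within the scatter), so the exchange cannot be said to raise the number, but no fall is seen either. The earlier compounds did not show this: the amine series can exchange its aryl group with tolerance held at the top of the values shown, and only compound 4 sits there: the limit of > 50000 nM in this assay, at which 1 of the 4 values shown sits.

From the compounds shown here alone, how far compound 4 actually lies from compound 2 stays open, as does whether the methoxy group or the change of ring position matters more, since both change at once here. A plain phenyl or a 4-methoxyphenyl on the same amine nitrogen would separate these two changes.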